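The source may hold more compounds than are shown below. What is called first, only, known or untested is meant among the compounds shown, and "the series" means these compounds.

Working notes on the series, read in a physicochemical assay for lipophilicity, read by HPLC, at pH 7.4; on this read-out lower numbers stand for lower lipophilicity and higher numbers for higher lipophilicity. Compound 1 `C[C@@H](Oc1cc2onc(CCC(=O)O)c2cc1Cl)c1ccc(Cl)cn1` gives 2.91 in this assay. Compound 2 `Cc1ccnc([C@@H](C)Oc2cc3oc(=O)n(CCC(=O)O)c3cc2Cl)c1` gives 2.15 in this assay, and compound 3 `O=C(O)CCn1c(=O)oc2cc(OCC3CCC3)c(Cl)cc21` gives 2.9 in this assay. Compound 2 therefore stands lowest of the three numbers shown: the nearest to it is compound 3, whose number lies higher by more than the scatter, and the furthest is compound 1, whose number lies higher still, also beyond the scatter. For the measured compounds named here, no two of the measured compounds differ in only one place, so no single-change step can be drawn from them.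

Compound 4 `Cc1cccc([C@@H](C)Oc2cc3oc(=O)n(CCC(=O)O)c3cc2Cl)n1` has not yet been measured. It holds the same atoms as compound 2, joined differently: 6-methylpyridin-2-yl in place of 4-methylpyridin-2-yl on a saturated chain carbon bound to an oxygen on an aromatic ring and a saturated chain carbon. The whole of the difference is 6-methylpyridin-2-yl in place of 4-methylpyridin-2-yl; the rest of compound 2 is carried over unchanged. Rearranging the same atoms within one six-membered aromatic ring gives no ground for a shift beyond the scatter, and the step from compound 2 to compound 4 in this assay is expected to be small, if anything a slight rise: a number 0.10 log units higher from compound 2 to compound 4 (within the scatter). Compound 4 is estimated at 2.25 in this assay, with a range from 1.95 to 2.6.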

Compound 4, distribution coefficient: 2.12
The estimate for compound 4 lay 0.13 log units above the measured number; the measured number falls inside the stated range.
By their numbers in this assay, from the lowest: compounds 4 and 2 (each within the scatter of the next); then compounds 3 and 1 (each within the scatter of the next).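

For the compounds shown here, with a number 0.03 log units lower from compound 2 to compound 4 (within the scatter) in this assay, 6-methylpyridin-2-yl in place of 4-methylpyridin-2-yl on a saturated chain carbon bound to an oxygen on an aromatic ring and a saturated chain carbon gives the first single-change step, and that step lies within the scatter. Going by these compounds alone, at this place, and on this core, the two isomeric methylpyridinyl groups therefore cannot be told apart in this assay, something no earlier comparison could show, since none of the earlier compounds differed in only one place. No available data bear on the reason for this result.

Within the data shown here, the step covers only this one exchange between two isomeric groups, so it leaves open whether this assay would stay as close with a different group at this place, such as an unsubstituted phenyl ring, a methoxy group on the pyridine or an amine on the pyridine. Among these compounds, compound 1 and compound 3 each differ from compound 2 and compound 4 in more than one place, so no steps to them can be read and the contribution of any single part of those structures remains unresolved.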